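Bare Phenyl in Place of a Substituted Aryl

The source may hold more compounds than are shown below. What is called first, only, known or untested is meant among the compounds shown, and "the series" means these compounds.

Among the compounds with values here, compound 3, `O=S(=O)(NCCCNCc1ccc(Cl)c(C(F)(F)F)c1)c1cc(C(F)(F)F)cc(C(F)(F)F)c1`, gives 5900 nM in a functional assay on A2780 cells (Homo sapiens) for inhibition, read by MTT assay, with a stated time of 72 h (on this read-out lower numbers stand for stronger inhibition of growth and higher numbers for weaker inhibition of growth), the second highest of the three numbers measured so far. Compound 2, `COc1ccc(CNCCCNS(=O)(=O)c2cc(C(F)(F)F)cc(C(F)(F)F)c2)cc1OC`, gives 3800 nM, and compound 1, `O=S(=O)(NCCCNCc1ccccc1Cl)c1cc(C(F)(F)F)cc(C(F)(F)F)c1`, gives 9300 nM. Both of these sit within the scatter of compound 3: a 1.6-fold higher number from compound 2 to compound 3 (0.19 log units; within the scatter) and a 1.6-fold lower number from compound 1 to compound 3 (0.20 log units; within the scatter). Within the data shown here, the only step that reaches beyond the scatter is a 2.4-fold lower number from compound 1 to compound 2 (0.39 log units; beyond the scatter), and even that one is modest.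

Compound 4, `O=S(=O)(NCCCNCc1ccccc1)c1cc(C(F)(F)F)cc(C(F)(F)F)c1`, differs from compound 3 in one place: phenyl in place of 4-chloro-3-(trifluoromethyl)phenyl on a saturated chain carbon bound to an amine nitrogen. Among the measured compounds shown here, the steps that bear on this change are the two that swap one aryl group for another on the same chain carbon, namely a 1.6-fold lower number from compound 1 to compound 3 (0.20 log units; within the scatter) and a 2.4-fold lower number from compound 1 to compound 2 (0.39 log units; beyond the scatter); the three aryl groups tried at that position span a narrow range. For the measured compounds named here, no measured compound yet removes both the chlorine and the trifluoromethyl at once, so the direction is uncertain, and a step of no more than modest size is expected, leaning toward a somewhat higher number. Compound 4 is therefore expected to give about 8000 nM, within a range from 3500 nM to 18000 nM, which would mean a 1.4-fold higher number from compound 3 to compound 4 (0.13 log units; within the scatter) in this assay.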

Compound 4, concentration for 50% growth inhibition: 4900 nM
Beside the measured number, compound 4's estimate is 1.6-fold (0.21 log units) above it; low and high end bracket the measured number.
By their numbers in this assay, from the lowest: compounds 2, 4, 3 and 1 (each within the scatter of the next, the first and the last beyond it).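

In this assay, reducing the aryl group on the saturated chain carbon bound to an amine nitrogen to a bare phenyl moves the number by no more than the scatter, both for the 4-chloro-3-(trifluoromethyl)phenyl group (a 1.2-fold lower number from compound 3 to compound 4 (0.08 log units; within the scatter)) and for the 3,4-dimethoxyphenyl group (a 1.3-fold higher number from compound 2 to compound 4 (0.11 log units; within the scatter)), so neither substituted aryl group is shown to be needed at this position. Hydrogen in place of chloro on an aromatic carbon also stays within the scatter (a 1.9-fold lower number from compound 1 to compound 4 (0.28 log units; within the scatter)), so compound 4 does not separate itself from compound 1 or compound 2, even though those two stand beyond the scatter of each other. The results shown offer no evidence that would account for how little these aryl changes matter.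

It remains open whether a carboxylic acid or an amine on the phenyl ring would give a step beyond the scatter, since every aryl group shown carries only chloro, trifluoromethyl or methoxy substituents, or none. A longer chain on the shared core, or a different group in place of the bis(trifluoromethyl)phenyl on the sulfonyl side, also remains untested by the compounds shown.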